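Aryl swap on a thiazole acetic acid series

The source may hold more compounds than are shown below. What is called first, only, known or untested is meant among the compounds shown, and "the series" means these compounds.

Within the data shown here, the three compounds measured so far share a core that carries an acetic acid chain, an aryl group and a second substituent. Compound 1 `CCC(c1ccccc1)c1nc(-c2ccc(Cl)cc2)c(CC(=O)O)s1` gives 190 nM in an in vitro assay on HEK385-7 cells for displacement of a labelled ligand from prostaglandin D2 receptor 2 (Homo sapiens); a higher number here means a weaker inhibitor, a lower number a stronger inhibitor. Compound 2 `O=C(O)Cc1sc(CSc2ccccc2)nc1-c1ccc(Cl)cc1` gives 250 nM in this assay. Compound 3 `O=C(O)Cc1sc(C(c2ccc(F)cc2)c2ccc(F)cc2)nc1-c1ccccc1` gives 16 nM in this assay, the lowest of the three numbers; the step from compound 3 to compound 1 and the step from compound 3 to compound 2 both lie beyond the scatter, so compound 3 stands as the strongest inhibitor among those measured.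

Compound 4 `CN(C)c1cc(-c2nc(C(c3ccc(F)cc3)c3ccc(F)cc3)sc2CC(=O)O)ccn1` has not yet been measured. It differs from compound 3 in one place: 2-(dimethylamino)pyridin-4-yl in place of phenyl on an aromatic carbon. Among the measured compounds shown here, no pair among the measured compounds shows a change of this kind, so the data give no directly comparable step. The account therefore rests on compound 3 alone, which gives 16 nM in this assay.

The step from compound 3 to compound 4 is expected to be small, a 1.6-fold higher number from compound 3 to compound 4 (0.19 log units; within the scatter), and could fall within the scatter in either direction. Compound 4 is estimated to give 25 nM in this assay, with a range from 6 nM to 100 nM.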

Compound 4, half-maximal inhibitory concentration: 380 nM
For compound 4 the middle estimate is 15-fold (1.18 log units) below the measured one; the measured number lies above the stated range.
By their numbers in this assay, from the lowest: compound 3; then compounds 1, 2 and 4 (each within the scatter of the next).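

At this aromatic carbon, next to the ring nitrogen and next to the ring atom that bears a carboxymethyl group, 2-(dimethylamino)pyridin-4-yl in place of phenyl gives a 24-fold higher number from compound 3 to compound 4 (1.38 log units; beyond the scatter) in this assay, a large step and beyond the scatter. Among these compounds, the earlier compounds offered no pair differing in one place, so this is the only direct reading of the position, and it shows that the number here depends strongly on which aryl group the position carries. The change brings in a ring nitrogen and a dimethylamino group together, so the step cannot assign the loss to either one, and no supporting measurement bears on why the number rises.

As far as these compounds go, it remains open how a plain pyridin-4-yl, or a phenyl carrying only a dimethylamino group, would read at this position, which would separate the share of the ring nitrogen from that of the amine. Also open, from the compounds shown here alone, is whether the same swap would give a step of similar size alongside the different second substituents of compound 1 and compound 2.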